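The source may hold more compounds than are shown below. What is called first, only, known or untested is meant among the compounds shown, and "the series" means these compounds.

In a functional assay on MCF7 cells (Homo sapiens) for inhibition, read by microscopy and colony formation, with a stated time of 10 days (a lower number here means a stronger inhibitor, a higher number a weaker inhibitor), compound 1 (`CCCCCCCCCCCCCCNC(=O)[C@H](CO)NCc1ccccc1`) gives 5000 nM and compound 2 (`CCCCCCCCCCCCCCNC(=O)[C@H](CO)/N=C/c1ccccc1`) gives 4700 nM as its value, so the two stand level. Among the measured compounds shown here, the only measured step is a 1.1-fold lower number from compound 1 to compound 2 (0.03 log units; within the scatter) and it kept the six-membered aromatic ring. Compound 3 (`CCCCCCCCCCCCCCNC(=O)[C@H](CO)NC(=O)C(C)(C)C`) is not yet measured, and the change to it is a group of 7 heavy atoms (5 carbon, 1 nitrogen, 1 oxygen; no ring) in place of a group of 8 heavy atoms (7 carbon, 1 nitrogen; one six-membered aromatic ring of carbon only), on a saturated chain carbon bound to a carbonyl carbon and a saturated chain carbon in one place, where ((tert-butyl)carbonyl)amino enters and that ring leaves. The measured step therefore offers weak guidance, and no step beyond the scatter is expected in this assay. The expected step is a 1.3-fold higher number from compound 2 to compound 3 (0.11 log units; within the scatter) in this estimate. Compound 3 is estimated at 6000 nM with an expected range from 2500 nM to 15000 nM overall.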

Compound 3, half-maximal inhibitory concentration: 6700 nM
The estimate for compound 3 lay 1.1-fold (0.05 log units) below the measured number, within the range that was stated.
By their numbers in this assay, from the lowest: compounds 2, 1 and 3 (each within the scatter of the next).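

In this assay, a group with no ring and an amide hydrogen, ((tert-butyl)carbonyl)amino, takes the place of the ring-bearing group on this saturated chain carbon, and the step is a 1.4-fold higher number from compound 2 to compound 3 (0.15 log units; within the scatter). On the amine nitrogen, the same comparison gives a 1.3-fold higher number from compound 1 to compound 3 (0.13 log units; within the scatter). So among these compounds, the six-membered aromatic ring is not required for a value in this range, and no measurement available here explains this. Still open, as far as these compounds go, is whether a free amine or a carboxylic acid at this place would give a step beyond the scatter. From the compounds shown here alone, the effect of a shorter chain in place of the long chain shared by all the compounds also remains open.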